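This account rests on a few compounds, and the source may have more. Where it says the series, first, only, none or still open, it means among the compounds named here.

Measured so far:
Compound 1 `Cc1cc(C)nc(-n2nc(C)c3c2NC(=O)CC3c2ccc(COc3cccc(Cl)c3)cc2)n1`: 3000 nM
Compound 2 `Cc1nn(-c2ncnc3nc[nH]c23)c2c1C(C(=O)N(C)c1nccs1)CC(=O)N2`: 3300 nM
Compound 3 `CCC(C(=O)NC1CC(=O)Nc2c1c(C)nn2-c1ncnc2nc[nH]c12)c1ccccc1`: 79 nM

Of the compounds shown here, three have been tested in a functional assay on HEK293 cells for agonist activity at G-protein coupled receptor 39 (Homo sapiens), read by scintillation proximity assay and inositol phosphate accumulation, with a stated time of 75 min; on this read-out lower numbers stand for an effect already at smaller amounts and higher numbers for an effect only at larger amounts of compound. Among them compound 2 stands at the highest of the three numbers. Compound 1 is its nearest neighbour, and the gap between compound 1 and compound 2 lies within the usual scatter of repeated measurements, so the two cannot be ordered. Compound 3 is furthest from compound 2, with the lower number, and that gap lies well beyond the scatter. No two of the measured compounds differ in only one place, so no single-point step can be read from the measured set.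

Compound 4 `Cc1nn(-c2ncnc3nc[nH]c23)c2c1C(OCC(C)C)CC(=O)N2` has not yet been measured. It differs from compound 2 in one place: isobutoxy in place of methyl(1,3-thiazol-2-yl)carbamoyl on a saturated ring carbon. For the measured compounds named here, nothing among the measured compounds shows this exchange, so its consequence in this assay is open; compound 2 gives 3300 nM as the only anchor. Because compound 3 reaches 79 nM with a different group at the same saturated ring carbon, a wide range is left open on the lower side. The step from compound 2 to compound 4 is expected to be a 1.7-fold lower number from compound 2 to compound 4 (0.22 log units; within the scatter), which is not beyond the scatter. Compound 4 is therefore estimated at 2000 nM in this assay, within a range from 300 nM to 12000 nM.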

Compound 4, half-maximal effective concentration: 111 nM
Beside the measured number, compound 4's estimate is 18-fold (1.26 log units) above it; the whole stated range lies above it.
By their numbers in this assay, from the lowest: compounds 3 and 4 (each within the scatter of the next); then compounds 1 and 2 (each within the scatter of the next).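

In this assay, replacing methyl(1,3-thiazol-2-yl)carbamoyl with isobutoxy on the saturated ring carbon gives a 30-fold lower number from compound 2 to compound 4 (1.47 log units; beyond the scatter), so a single exchange at this position can move the number well beyond the scatter. The entering group has no ring and fewer heavy atoms than the group that leaves, so compound 4 shows that a low number at this carbon does not need the five-membered aromatic ring or the carbamoyl; compound 4 at 111 nM and compound 3 at 79 nM stand within the scatter of each other despite their different groups at this carbon. No measurement at hand accounts for the size of this step.

The compounds shown leave open whether the lower number follows the ether oxygen or the branched chain, which a methoxy group, a straight butoxy chain or an isobutyl group joined directly to the ring carbon would help to separate. They also leave open how an amine or a carboxylic acid at this saturated ring carbon would read in this assay.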